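The source may report more compounds than this note shows. Statements on the series, on what has been measured and on what is new or still open speak of the compounds shown alone.

Compound 1 `COc1cc(-c2nccn2C)cc(OC)c1OC`: "not determined" (no result reported)
Compound 2 `COc1cc(-c2nccn2-c2cccc(C)c2)cc(OC)c1OC`: > 100000 nM
Compound 3 `COc1cccc(-n2ccnc2-c2cc(OC)c(OC)c(OC)c2)c1`: "not determined" (no result reported)

These three compounds share a core and were examined in an ADME assay on HUVEC cells (Homo sapiens) for cytotoxicity, read by MTT assay, with a stated time of 72 h; on this read-out higher numbers stand for weaker inhibition and lower numbers for stronger inhibition. Compound 1 stands without a number there: its entry carries no result at all. Compound 3 is in the same position, with no result reported. Compound 2 is the only one with an entry, and that entry is a limit of the assay rather than a number. Of the values shown, (the limit of > 100000 nM in this assay, at which 1 of the 3 values shown sits). Among the compounds with values here, no step between two measured compounds can therefore be drawn, and no size of change is known from the measured set.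

The unmeasured compound is compound 4 `COc1cc(-c2nccn2-c2ccc(Br)cc2)cc(OC)c1OC`. It differs from compound 1 in one place: 4-bromophenyl in place of methyl on an aromatic nitrogen. Within the data shown here, since compound 1 itself has no number, the only anchor is compound 2, which carries an aryl group at the same ring nitrogen and gives only a limit, > 100000 nM, in this assay. On that footing no step beyond the scatter is expected in this assay, and the expectation for compound 4 is likewise a weak result near the limit.

Compound 4 is expected to give about 100000 nM in this assay, with a range from 30000 nM to 300000 nM, and most likely the assay will report only a limit.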

Compound 4, half-maximal inhibitory concentration: > 100000 nM
Compound 4 was reported as a limit (the forecaster's own chance of this, stated with the estimate: 70%); the middle value sits exactly at the limit.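

Compound 2 and compound 4 both stand as limits with no number in this assay, so the step between them, 4-bromophenyl in place of 3-methylphenyl on an aromatic nitrogen, cannot be read: the limit of > 100000 nM in this assay, at which 2 of the 4 values shown sit. The compounds shown leave open how compound 2 and compound 4 compare with compound 1, which has no reported result in this assay.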